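The compounds below may be only part of what the source reports. "The series", "measured", "known", "first", "only" and "open" are said of these compounds alone.

Compound 2 `COc1cc(-c2nnc3n2NC(c2ccco2)C(C(=O)c2cccc4ccccc24)S3)cc(OC)c1OC` was tested in a functional assay on HepG2 cells (Homo sapiens) for cytotoxicity, read by MTT assay, with a stated time of 48 h (a lower number here means a stronger inhibitor, a higher number a weaker inhibitor), where compound 2 gives 33900 nM. The nearest comparison is compound 1 `COc1cc(-c2nnc3n2NC(c2ccco2)C(C(=O)c2cccs2)S3)cc(OC)c1OC`, which in this assay gives 64100 nM; the step of a 1.9-fold lower number from compound 1 to compound 2 (0.28 log units; within the scatter) shows that these two numbers sit within the scatter of each other. Compound 3 `COc1cc(-c2nnc3n2NC(c2ccco2)C(C(=O)c2ccc(F)c(F)c2)S3)cc(OC)c1OC` carries 3,4-difluorophenyl in place of naphthalen-1-yl on a carbonyl carbon. For the measured compounds named here, the only measured step at that carbonyl carbon, a 1.9-fold lower number from compound 1 to compound 2 (0.28 log units; within the scatter), stayed within the scatter, so a further exchange there is expected to give no step beyond the scatter, a 1.2-fold higher number from compound 2 to compound 3 (0.07 log units; within the scatter). For compound 3 in this assay the estimate is 40000 nM, between 15000 nM and 110000 nM.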

Compound 3, half-maximal inhibitory concentration: 52400 nM
Compound 3: middle estimate off by 1.3-fold (0.12 log units), on the low side, and the stated range covers the measured number.
By their numbers in this assay, from the lowest: compounds 2, 3 and 1 (each within the scatter of the next).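

In this assay, a third group on the carbonyl carbon gives the same picture: both a 1.5-fold higher number from compound 2 to compound 3 (0.19 log units; within the scatter) and a 1.2-fold lower number from compound 1 to compound 3 (0.09 log units; within the scatter) stay within the scatter, so thiophen-2-yl, naphthalen-1-yl and 3,4-difluorophenyl cannot be told apart at this position. Even the exchange of the two-ring naphthalen-1-yl for the one-ring, fluorine-bearing 3,4-difluorophenyl produces no step beyond the scatter. Nothing available explains why these groups read alike.

From the compounds shown here alone, whether a group without an aromatic ring, such as an amine or a carboxylic acid on a short chain, would move the number at this carbonyl carbon stays open. So does the effect of any change elsewhere on the shared core.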